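Swapping the benzoyl for an acetyl on a vinyl sulfone

The source may hold more compounds than are shown below. What is called first, only, known or untested is meant among the compounds shown, and "the series" means these compounds.

Measured compounds:
- compound 1 `N#C/C(=C\c1c(-c2ccccc2)[nH]c2ccccc12)C(=O)c1ccccc1`: 5300 nM
- compound 2 `O=C(/C(=C\c1c(-c2ccccc2)[nH]c2ccccc12)S(=O)(=O)c1ccccc1)c1ccccc1`: 3400 nM
- compound 3 `COc1ccc(-c2[nH]c3ccc(OC)cc3c2/C=C(\C#N)S(=O)(=O)c2ccccc2)cc1`: 905 nM

In a functional assay on T47D cells (Homo sapiens) for inhibition, read by sulforhodamine B assay, with a stated time of 48 h (a lower number here means a stronger inhibitor of growth, a higher number a weaker inhibitor of growth), compound 2 gives 3400 nM, the second highest of the three numbers. Its nearest neighbour is compound 1, which sits within the scatter, while compound 3 gives a number beyond the scatter and clearly lower. Compound 4 `CC(=O)/C(=C\c1c(-c2ccccc2)[nH]c2ccccc12)S(=O)(=O)c1ccccc1` has not yet been measured. It differs from compound 2 in one place: methyl in place of phenyl on a carbonyl carbon. Within the data shown here, no measured pair shows this change, so only an expectation can be given. A small step, probably towards a weaker inhibitor of growth, is expected, but one that may well stay within the scatter. Compound 4 is therefore estimated at 4500 nM, in a range from 1500 nM to 13000 nM, which means an expected step of a 1.3-fold higher number from compound 2 to compound 4 (0.12 log units; within the scatter).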

Compound 4, concentration for 50% growth inhibition: 1400 nM
Estimate against measurement, compound 4: 3.2-fold (0.51 log units) above; measured number below the stated range.
By their numbers in this assay, from the lowest: compounds 3 and 4 (each within the scatter of the next); then compounds 2 and 1 (each within the scatter of the next).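

On this carbonyl carbon, the phenyl is not needed for growth inhibition: methyl in its place gives a 2.4-fold lower number from compound 2 to compound 4 (0.39 log units; beyond the scatter) and is a modest step beyond the scatter. Among these compounds, this is the first pair that differs in one place, so it is the first direct reading of this position, and benzoyl to acetyl goes with a stronger inhibitor of growth. Nothing available here explains this step. On these data alone, it remains open whether the gain holds with an ethyl or a longer chain on the carbonyl carbon, or with an amine there, which would make an amide.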